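Moving the attachment from quinolin-8-yl to quinolin-6-yl

The compounds below may be only part of what the source reports. "The series", "measured", "known", "first", "only" and "open" are said of these compounds alone.

Among the measured compounds shown here, in a functional assay on DU-145 cells (Homo sapiens) for inhibition, read by trypan blue exclusion, with a stated time of 72 h (a higher number here means a weaker inhibitor, a lower number a stronger inhibitor), compound 1 `Cc1ccc(S(=O)(=O)c2cc3cnc(Nc4cnc5[nH]ccc5c4)nc3n(C)c2=O)cc1` gives 25000 nM as the higher of the two numbers so far. Compound 2 `Cc1ccc(S(=O)(=O)c2cc3cnc(Nc4cccc5cccnc45)nc3n(C)c2=O)cc1` gives 10000 nM and so stands lowest. For the measured compounds named here, the only measured step is a 2.5-fold lower number from compound 1 to compound 2 (0.40 log units; beyond the scatter) and it came with the exchange of one whole group on the nitrogen for a different one.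

Compound 3 `Cc1ccc(S(=O)(=O)c2cc3cnc(Nc4ccc5ncccc5c4)nc3n(C)c2=O)cc1` has the same atoms as compound 2, joined differently: quinolin-6-yl in place of quinolin-8-yl on a nitrogen on an aromatic ring. In plain words, quinolin-6-yl stands in place of quinolin-8-yl on a nitrogen on an aromatic ring. Going by the values given here, the one measured step bears on this only loosely, and no measured pair shows what such a shift of attachment does. A change no larger than that step is expected in this assay and the data offer no firm direction, so the estimate stays close to compound 2. The expected change is a 1.3-fold lower number from compound 2 to compound 3 (0.10 log units; within the scatter) and no clear move beyond the scatter is anticipated. Compound 3 is estimated at 8000 nM within an expected range of 2500 nM to 25000 nM.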

Compound 3, half-maximal inhibitory concentration: 10000 nM
Estimate against measurement, compound 3: 1.3-fold (0.10 log units) below; measured number inside the range.
By their numbers in this assay, from the lowest: compounds 2 and 3 (each within the scatter of the next); then compound 1.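

In this assay the move from quinolin-8-yl to quinolin-6-yl on the nitrogen gives no change at the digits printed from compound 2 to compound 3 (within the scatter), and this pair is the only one shown in which the point of attachment alone differs, so at this position that shift has no readable effect on the number. The exchange of the group in compound 1 for quinolin-6-yl gives a 2.5-fold lower number from compound 1 to compound 3 (0.40 log units; beyond the scatter), a step of the same size as the one already seen with quinolin-8-yl, which places the two attachments together on the same side of compound 1 and shows that the modest gain from that exchange does not rest on one particular point of attachment. Nothing at hand explains why the two attachments read alike or why both stand apart from compound 1.

The compounds shown leave open whether a different kind of group on this nitrogen, such as a phenyl ring carrying a piperazine or a morpholine, would move the number by more than these modest steps. They also leave open whether the other quinolinyl attachments would read the same as these two, and whether a change elsewhere on the shared core would matter more than any change at this nitrogen.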